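Benzyl-ether variations on the pyridinyl benzamide core

This account rests on a few compounds, and the source may have more. Where it says the series, first, only, none or still open, it means among the compounds named here.

Three compounds share the core of compound 1 `O=C(Nc1cccnc1)c1ccccc1OCc1ccccc1F` and differ only in the aryl group on the saturated chain carbon bound to an oxygen on an aromatic ring. In an assay on lysate for inhibition of phosphatidylcholine:ceramide cholinephosphotransferase 2 (Homo sapiens), read by HPLC, with stated times of 30 min and 2 h (a higher number here means a weaker inhibitor, a lower number a stronger inhibitor), compound 1 gives 3500 nM. Compound 2 `O=C(Nc1cccnc1)c1ccccc1OCc1cccc(Cl)c1` gives 1400 nM, and compound 3 `O=C(Nc1cccnc1)c1ccccc1OCc1c(F)cccc1Cl` gives 1500 nM. Compound 3 therefore stands second highest of the three numbers: it sits within the scatter of compound 2 (a 1.1-fold higher number from compound 2 to compound 3 (0.03 log units; within the scatter)), and both lie clearly below compound 1 (a 2.3-fold lower number from compound 1 to compound 3 (0.37 log units; beyond the scatter), a 2.5-fold lower number from compound 1 to compound 2 (0.40 log units; beyond the scatter)).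

Compound 4 `O=C(Nc1cccnc1)c1ccccc1OCc1cc(Cl)ccc1Cl` has not been measured. Its change from compound 3 is 2,5-dichlorophenyl in place of 2-chloro-6-fluorophenyl on a saturated chain carbon bound to an oxygen on an aromatic ring. Within the data shown here, two measured steps bear on it. The step of a 2.3-fold lower number from compound 1 to compound 3 (0.37 log units; beyond the scatter) shows that adding a chloro to the benzylic aryl group gives a modest gain, and a 2.5-fold lower number from compound 1 to compound 2 (0.40 log units; beyond the scatter) shows the same size of gain for a chloro in another arrangement; yet a 1.1-fold higher number from compound 2 to compound 3 (0.03 log units; within the scatter) shows that once one chloro is present, rearranging the halogens leaves the number unchanged within the scatter. Compound 4 keeps one chloro and adds a second in place of the fluorine, so the expectation for this assay is a step of a 1.3-fold lower number from compound 3 to compound 4 (0.10 log units; within the scatter), that is, none beyond the scatter or at most a small drop. Compound 4 is therefore estimated at 1200 nM, with a range from 500 nM to 3000 nM.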

Compound 4, half-maximal inhibitory concentration: 990 nM
Estimate against measurement, compound 4: 1.2-fold (0.08 log units) above; measured number inside the range.
By their numbers in this assay, from the lowest: compounds 4, 2 and 3 (each within the scatter of the next); then compound 1.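

In this assay, a second chlorine on the aryl group does not separate compound 4 from the monochloro compound, with a 1.4-fold lower number from compound 2 to compound 4 (0.15 log units; within the scatter), and exchanging the fluorine-bearing aryl group for 2,5-dichlorophenyl does not separate it from the mixed-halogen compound either, with a 1.5-fold lower number from compound 3 to compound 4 (0.18 log units; within the scatter). The 2-fluorophenyl compound remains the only one set apart, with a 3.5-fold lower number from compound 1 to compound 4 (0.55 log units; beyond the scatter), so on these four compounds the halogen pattern at this position resolves into two levels: compound 1 alone, and compounds 2, 3 and 4 together. Chloro in place of hydrogen can now be read twice at this position, and the two readings do not differ measurably: the same change on two cores in this assay, a 2.3-fold lower number (0.37 log units; beyond the scatter) from compound 1 to compound 3 and a 1.4-fold lower number (0.15 log units; within the scatter) from compound 2 to compound 4, 1.7-fold (0.22 log units) apart, within the scatter of two such steps.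

Going by these compounds, all four compounds carry only halogens on this aryl group, so what a methoxy group, a nitrile, an amine or a carboxylic acid would do on a saturated chain carbon bound to an oxygen on an aromatic ring stays open. Also open, on these data alone, are a longer chain in place of that single carbon and whether the chloro step holds on any other core.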